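A few compounds are considered here, and "the series" means these few. Any claim that something is new, unique, unknown or untested is made for them only; others in the source may bear on it.

Of the compounds shown here, three on one shared core have been read in a functional assay on T-24 cells (Homo sapiens) for antiproliferative activity, read by MTT assay, with a stated time of 48 h; on this read-out lower numbers stand for stronger inhibition and higher numbers for weaker inhibition: compound 1 (`COc1ccc(NC(=O)Nc2cccc(CNc3nccnc3Cl)c2)cc1`) gives 9820 nM, compound 2 (`O=C(Nc1cccc(Cl)c1)Nc1cccc(CNc2nccnc2Cl)c1`) gives 6810 nM and compound 3 (`O=C(Nc1ccc(C(F)(F)F)cc1)Nc1cccc(CNc2nccnc2Cl)c1`) gives 4580 nM. Compound 3 cannot be separated from compound 2, as their two values lie within the scatter of each other. The only separation in the set is a 2.1-fold lower number from compound 1 to compound 3 (0.33 log units; beyond the scatter), a modest step.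

Compound 4 (`Cc1ccc(NC(=O)Nc2cccc(CNc3nccnc3Cl)c2)cc1`) has not been measured. It carries methyl in place of trifluoromethyl on an aromatic carbon.

Among the measured compounds shown here, two measured steps bear on this change. The closer one is a 2.1-fold lower number from compound 1 to compound 3 (0.33 log units; beyond the scatter), where trifluoromethyl replaces methoxy on the same aromatic carbon. The other, a 1.4-fold lower number from compound 1 to compound 2 (0.16 log units; within the scatter), swaps 4-methoxyphenyl for 3-chlorophenyl and stays within the scatter. For the measured compounds named here, no methyl compound has been measured, so the direction rests on that single modest step. All three values sit close together, so only a small move in this assay is expected, toward a higher number and probably within the scatter. The expected step is a 1.5-fold higher number from compound 3 to compound 4 (0.18 log units; within the scatter). For compound 4 the estimated value is 7000 nM, with an expected range of 3500 nM to 13000 nM.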

Compound 4, half-maximal inhibitory concentration: 9820 nM
The estimate for compound 4 lay 1.4-fold (0.15 log units) below the measured number; measured number inside the range.
By their numbers in this assay, from the lowest: compounds 3, 2, 1 and 4 (each within the scatter of the next, the first and the last beyond it).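

In this assay, the change on the aromatic carbon para to a large group gives a 2.1-fold higher number from compound 3 to compound 4 (0.33 log units; beyond the scatter), a modest step beyond the scatter, so methyl does not keep the number seen with trifluoromethyl. At this carbon, the step with methyl in place of methoxy shows no change at the digits printed from compound 1 to compound 4 (within the scatter), which puts these two groups together at the read-out and leaves trifluoromethyl as the only one of the three separated from both. Across an aryl change, the reading a 1.4-fold higher number from compound 2 to compound 4 (0.16 log units; within the scatter) stays within the scatter, so 4-methylphenyl cannot be told apart from 3-chlorophenyl, and the separation of compound 3 from compound 4 does not extend to a separation of compound 2 from compound 4.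

No measurement at hand addresses what lies behind the difference between trifluoromethyl and methyl at this position. As far as these compounds go, it remains open whether a nitrile or a carboxylic acid on the same aromatic carbon would read with trifluoromethyl or with methyl and methoxy, and whether any such change would move the series by more than this modest step.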